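This account rests on a few compounds, and the source may have more. Where it says the series, first, only, none or still open, it means among the compounds named here.

Measured so far in a functional assay on brain (Rattus norvegicus, strain Wistar) for inhibition; a higher number here means a weaker inhibitor, a lower number a stronger inhibitor:
Compound 1, `CCCc1ccc(-c2c(C)[nH]c(=O)n2C)cc1`, 21500 nM
Compound 2, `CCCCCOc1ccc(-c2c(C)[nH]c(=O)n2C)cc1`, 4500 nM
Compound 3, `CCCc1ccc(-c2c(C)[nH]c(=O)n2C2CCCCC2)cc1`, 13900 nM

Compound 3 stands second highest of the three numbers. Its nearest neighbour is compound 1, a 1.5-fold lower number from compound 1 to compound 3 (0.19 log units; within the scatter), a step within the scatter, so the two cannot be ordered against each other. The furthest is compound 2: compound 3 at 13900 nM sits well above compound 2 at 4500 nM.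

Compound 4, `CCCCCCCc1ccc(-c2c(C)[nH]c(=O)n2C2CCCCC2)cc1`, is not yet measured. Against compound 3 the change is butyl in place of hydrogen on a saturated chain carbon, three bonds along the chain from an aromatic carbon, which reads as propyl to heptyl on the aromatic carbon. Among the compounds with values here, the only measured step that bears on this position is a 4.8-fold lower number from compound 1 to compound 2 (0.68 log units; beyond the scatter), a modest drop beyond the scatter, though pentyloxy is not a pure chain extension of propyl. The step of a 1.5-fold lower number from compound 1 to compound 3 (0.19 log units; within the scatter) concerns the aromatic nitrogen and is within the scatter, so it adds nothing here. A single informative step is thin support, but it points in one direction: a longer group at this carbon is expected to lower the number in this assay by a modest amount, a 2.5-fold lower number from compound 3 to compound 4 (0.40 log units; beyond the scatter).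

Compound 4 is therefore estimated at 5500 nM in this assay, with a range from 2000 nM to 15000 nM.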

Compound 4, half-maximal inhibitory concentration: 8700 nM
For compound 4 the middle estimate is 1.6-fold (0.20 log units) below the measured one; measured number inside the range.
By their numbers in this assay, from the lowest: compounds 2, 4, 3 and 1 (each within the scatter of the next, the first and the last beyond it).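

In this assay, the step on the cyclohexyl compounds, a 1.6-fold lower number from compound 3 to compound 4 (0.20 log units; within the scatter), shows that lengthening propyl to heptyl on the aromatic carbon gives no readable change, so the butyl added to the saturated chain does not separate compound 3 from compound 4. Within the data shown here, the only earlier step at this carbon, a 4.8-fold lower number from compound 1 to compound 2 (0.68 log units; beyond the scatter), lies beyond the scatter, but it brings in pentyloxy and has methyl rather than cyclohexyl on the aromatic nitrogen, so chain length alone does not carry that step over to the cyclohexyl compounds. No measurement on hand offers an explanation for this difference between the two steps.

The compounds shown leave open whether the earlier step belongs to the pentyloxy group itself or depends on the group on the aromatic nitrogen, a question that pentyloxy paired with cyclohexyl, or heptyl paired with methyl, would address directly. They also leave open how this assay responds to a chain longer than heptyl, or to an amine or a carboxylic acid in place of the heptyl group.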